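This account rests on a few compounds, and the source may have more. Where it says the series, first, only, none or still open, it means among the compounds named here.

Of the compounds shown here, three have been measured in a functional assay on NCI-H520 cells (Homo sapiens) for inhibition, read by MTT assay, with a stated time of 48 h, tested at 10 uM; a higher number here means more inhibition at the concentration tested (going by the name of the read-out), a lower number less inhibition. Compound 1, with the structure `COc1ccc(Br)cc1Nc1cc(NC(=O)Nc2c(Cl)cccc2Cl)ncn1`, gives 45%. Compound 2, with the structure `COc1cc(NC(=O)Nc2cc(Nc3ccc(C)c(F)c3)ncn2)cc(OC)c1`, gives 30.6%. Compound 3, with the structure `COc1cc(Nc2cc(NC(=O)Nc3c(Cl)cccc3Cl)ncn2)cc(C(F)(F)F)c1`, gives 23.1%.

On these numbers compound 2 stands second highest of the three. Its value and that of compound 3 lie within the usual scatter of each other, so the two cannot be told apart. The value of compound 1 lies beyond the scatter above that of compound 2, so compound 1 shows more inhibition than compound 2.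

Compound 4, with the structure `COc1cc(NC(=O)Nc2cc(Nc3ccc(C(C)(C)C)cc3)ncn2)cc(OC)c1`, has not yet been measured in this assay. It differs from compound 2 in one place: 4-(tert-butyl)phenyl in place of 3-fluoro-4-methylphenyl on a nitrogen on an aromatic ring. For the measured compounds named here, no pair among the measured compounds differs in just one place, so no measured step offers a direct guide for this change. The two groups involved are of similar size and neither carries hydrogen-bond donors or acceptors.

Going by the values given here, with no measured step to lean on, the expected step of a number 0.6 percentage points lower from compound 2 to compound 4 (within the scatter) is small, none beyond the scatter, in either direction. Compound 4 is therefore expected to give about 30%, with a range from 12% to 52%.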

Compound 4, a percentage reported as inhibition, at one concentration (the size of the read-out at that concentration, not a potency): 17.5%
Compound 4: the middle estimate sits 12.5 percentage points above what was measured; measured number inside the range.
By their numbers in this assay, from the lowest: compounds 4, 3 and 2 (each within the scatter of the next, the first and the last beyond it); then compound 1.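

In this assay, placing 4-(tert-butyl)phenyl in place of 3-fluoro-4-methylphenyl on the nitrogen on an aromatic ring gives a number 13.1 percentage points lower from compound 2 to compound 4 (beyond the scatter). For the compounds shown here, this is the first comparison between two compounds that differ in only one place, and it shows that the group at this position can change the read-out, even though both groups contain one six-membered aromatic ring of carbon only and neither has hydrogen-bond donors or acceptors. No measurement shown here accounts for the drop.

This single step changes several things at once, since the fluorine leaves and the methyl gives way to a tert-butyl, so it cannot show which of these matters, nor whether the same swap would have a similar effect in compounds built on the rest of compound 1 or compound 3. It also leaves open how the read-out would respond to a plain phenyl, or to a ring carrying an amine or a carboxylic acid, on that same nitrogen.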